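The source may report more compounds than this note shows. Statements on the series, on what has been measured and on what is new or still open speak of the compounds shown alone.

Of the compounds shown here, three have so far been measured in a functional assay on PC-3 cells (Homo sapiens); a lower number here means a stronger inhibitor of growth, a higher number a weaker inhibitor of growth. Compound 3 `O=S(=O)(/C=C/c1ccc(Cl)cc1)Cc1ccc(Nc2ncnc3ccc(Br)cc23)cc1` gives 2000 nM. Compound 2 `O=S(=O)(/C=C/c1ccc(Cl)c(Cl)c1)Cc1ccc(Nc2ncnc3ccc(Br)cc23)cc1` gives 11000 nM in this assay, and compound 1 `O=S(=O)(/C=C/c1ccc(Cl)cc1Cl)Cc1ccc(Nc2ncnc3ccccc23)cc1` gives 19000 nM. The change from compound 3 to compound 2 is chloro in place of hydrogen on an aromatic carbon and it brought a 5.5-fold higher number from compound 3 to compound 2 (0.74 log units; beyond the scatter). How the core of compound 1 differs from that of compound 3 is not broken down here. Compound 4 `O=S(=O)(/C=C/c1ccc(Cl)cc1Cl)Cc1ccc(Nc2ncnc3cc(Cl)ccc23)cc1` has not yet been measured; it differs from compound 1 by chloro in place of hydrogen on an aromatic carbon. This is the same kind of change, not the same one: in compound 2 the chloro sits ortho to a chloro group and meta to a large group, while in compound 4 it sits on a ring that is part of a fused system of two rings, meta and para to a fused ring. Compound 4 is therefore expected to give about 15000 nM in this assay, somewhere between 5000 nM and 50000 nM. That expectation means a 1.3-fold lower number from compound 1 to compound 4 (0.10 log units; within the scatter), and it rests loosely on a 5.5-fold higher number from compound 3 to compound 2 (0.74 log units; beyond the scatter). The place of the new chloro is different, and that step is taken only as a rough guide.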

Compound 4, concentration for 50% growth inhibition: 38000 nM
Compound 4: middle estimate off by 2.5-fold (0.40 log units), on the low side; measured number inside the range.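

Placing a chloro on the fused system of two rings gave a 2.0-fold higher number from compound 1 to compound 4 (0.30 log units; within the scatter) in this assay, a step that cannot be told apart from repeat-measurement noise. Set beside the earlier step, the same kind of change did not carry over at the same size from one core to the other: the same change on two cores in this assay, a 5.5-fold higher number (0.74 log units; beyond the scatter) from compound 3 to compound 2 and a 2.0-fold higher number (0.30 log units; within the scatter) from compound 1 to compound 4, 2.8-fold (0.44 log units) apart, beyond the scatter of two such steps. This does not show what sets the two steps apart, since the chloro sits in a different place in each pair and the cores differ too, and two pairs give no general rule.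

The compounds shown leave open how a methoxy group or an amine would fare in the place of this chloro. They also leave open what the same chloro, in the same place, would do on the core of compound 3.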